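Changing the Pendant Group on a Shared Core

This account rests on a few compounds, and the source may have more. Where it says the series, first, only, none or still open, it means among the compounds named here.

Of the compounds shown here, three built on one shared core have been measured. In a functional assay on MCF7 cells (Homo sapiens) for inhibition, read by CCK-8 assay, with a stated time of 48 h (a lower number here means a stronger inhibitor, a higher number a weaker inhibitor), compound 1 `COc1cc(-c2ccnc3cc(-c4ccc(C(C)=O)cc4)nn23)cc(OC)c1OC` gives 5230 nM. Compound 2 `COc1cc(-c2ccnc3cc(-c4ccc5ccn(C)c5c4)nn23)cc(OC)c1OC` gives 74 nM in this assay, and compound 3 `COc1cc(-c2ccnc3cc(-c4ccc(N(C)C)cc4)nn23)cc(OC)c1OC` gives 44 nM in this assay. Compound 3 thus shows the lowest number of the three, although its gap to compound 2 lies within the scatter, while the gap to compound 1 is large: a 120-fold lower number from compound 1 to compound 3 (2.08 log units; beyond the scatter).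

Compound 4 `COc1cc(-c2ccnc3cc(-c4cccc(C)c4)nn23)cc(OC)c1OC` has not yet been measured. It differs from compound 3 as follows: 3-methylphenyl in place of 4-(dimethylamino)phenyl on an aromatic carbon. The measured steps that bear on this are a 120-fold lower number from compound 1 to compound 3 (2.08 log units; beyond the scatter) and a 71-fold lower number from compound 1 to compound 2 (1.85 log units; beyond the scatter), both showing that the group attached at this point of the shared core shifts the number a great deal, whereas a 1.7-fold lower number from compound 2 to compound 3 (0.23 log units; within the scatter) shows two rather different groups giving numbers within the scatter of each other. Going by the values given here, no measured compound carries a 3-methylphenyl group here, so the expectation rests on analogy alone: the dimethylamino group is lost and no group resembling the groups of compound 2 or compound 3 enters. Compound 4 is therefore expected to give a higher number than compound 3, with the step estimated as an 11-fold higher number from compound 3 to compound 4 (1.06 log units; beyond the scatter). The estimate for compound 4 in this assay is 500 nM, expected to fall between 100 nM and 2500 nM.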

Compound 4, half-maximal inhibitory concentration: 1080 nM
Beside the measured number, compound 4's estimate is 2.2-fold (0.33 log units) below it; the range from low to high includes it.
By their numbers in this assay, from the lowest: compounds 3 and 2 (each within the scatter of the next); then compound 4; then compound 1.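

In this assay, the change to 3-methylphenyl brings a 25-fold higher number from compound 3 to compound 4 (1.39 log units; beyond the scatter), and replacing 1-methyl-1H-indol-6-yl with the same group brings a 15-fold higher number from compound 2 to compound 4 (1.16 log units; beyond the scatter), so the two groups whose numbers lie within the scatter of each other both stand clearly apart from this simpler aryl group. The 3-methylphenyl group is still not the poorest seen at this place, as replacing 4-acetylphenyl with it gives a 4.8-fold lower number from compound 1 to compound 4 (0.69 log units; beyond the scatter), a modest step compared with the other two. Across these four compounds, the nitrogen-bearing groups of compound 2 and compound 3 go with the lowest numbers, while the groups without nitrogen in compound 1 and compound 4 go with higher ones, and no compound here goes against this.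

No available evidence accounts for these shifts. The compounds shown leave open how 4-methylphenyl, 3-(dimethylamino)phenyl, or a phenyl ring carrying a methoxy group or a primary amine would compare, and so whether the lower numbers follow the nitrogen itself or some other feature of those groups.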